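Compound 1: carboxy to ethoxycarbonyl

This account rests on a few compounds, and the source may have more. Where it says the series, first, only, none or still open, it means among the compounds named here.

- compound 1 `O=C(O)c1cc(-c2ccc(Oc3ccccc3)cc2)nn1C1CCCN(C(=O)CCl)C1` gives 2200 nM
- compound 2 `C/C=C/C(=O)Nc1ccc(Cn2nc(-c3ccc(Oc4ccccc4)cc3)cc2CO)cc1` gives 12200 nM
- compound 3 `C=CC(=O)N1CCCC(n2nc(-c3ccc(Oc4ccccc4)cc3)cc2C(=O)O)C1` gives 50000 nM

In a functional assay on Rec1 cells (Homo sapiens) for inhibition, read by luminescence and CellTiter-Glo, with a stated time of 72 h (on this read-out higher numbers stand for weaker inhibition and lower numbers for stronger inhibition), compound 1 gives 2200 nM as the lowest of the three numbers. Compound 4 `CCOC(=O)c1cc(-c2ccc(Oc3ccccc3)cc2)nn1C1CCCN(C(=O)CCl)C1` differs from it by ethyl in place of hydrogen on an oxygen next to a carbonyl group, that is, carboxy to ethoxycarbonyl. For the measured compounds named here, no measured step covers this change. Going by the values given here, the one measured step, a 23-fold higher number from compound 1 to compound 3 (1.36 log units; beyond the scatter), lies elsewhere, at vinyl in place of chloromethyl on a carbonyl carbon, and serves only as a reminder that large steps occur here. Direction therefore stays open in this assay and a wide range is kept. The expected step is a 1.2-fold lower number from compound 1 to compound 4 (0.09 log units; within the scatter). For compound 4 the estimate is 1800 nM with an expected range from 400 nM to 8000 nM.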

Compound 4, half-maximal inhibitory concentration: 400 nM
Compound 4: the middle estimate sits 4.5-fold (0.65 log units) above what was measured, within the range that was stated.
By their numbers in this assay, from the lowest: compound 4; then compound 1; then compound 2; then compound 3.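

In this assay the change from carboxy to ethoxycarbonyl gives a 5.5-fold lower number from compound 1 to compound 4 (0.74 log units; beyond the scatter) and so shows that this position, and not only the chloromethyl on the other carbonyl carbon, moves the number. The free carboxy group of compound 1 is therefore not required for activity on this read-out, and the direction here is towards stronger inhibition. Nothing at hand accounts for this step.

Still open, from the compounds shown here alone, is how methoxycarbonyl, a longer alkoxycarbonyl chain or a primary amide would compare at this position. Also open, going by these compounds, is whether ethoxycarbonyl gives a similar step alongside the vinyl of compound 3.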